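A Chloro Swap and a Half-Life Still Unknown

This account rests on a few compounds, and the source may have more. Where it says the series, first, only, none or still open, it means among the compounds named here.

In an ADME assay on CCRF-CEM cells (Homo sapiens) for metabolic stability, read by HPLC (on this read-out higher numbers stand for a longer-lived compound and lower numbers for a shorter-lived compound), compound 1 `CCCCCCCCCCCCCCCCOC(=O)Oc1ccc(COP(=O)(OCc2ccc(OC(=O)CC)cc2)OP(=O)(O)OP(=O)(O)OC[C@@H]2O[C@H](n3cc(F)c(N)nc3=O)CS2)cc1` gives 1.49 h and compound 2 `CCCCCCCCCCCCCCCCOC(=O)Oc1ccc(COP(=O)(OCc2ccc(OC(=O)CC)cc2)OP(=O)(O)OP(=O)(O)OC[C@H]2O[C@@H](n3ccc(=O)[nH]c3=O)C[C@H]2N=[N+]=[N-])cc1` gives 1.54 h. These two numbers lie within the usual scatter of repeated measurements, so compound 2 stands level with compound 1 and the pair cannot be ranked. Compound 3 `CCCCCCCCCCCCCCCCOC(=O)Oc1ccc(COP(=O)(OCc2ccc(OC(=O)CC)cc2)OP(=O)(O)OP(=O)(O)OC[C@H]2O[C@@H](n3cc(Cl)c(=O)[nH]c3=O)C[C@H]2N=[N+]=[N-])cc1` has not yet been measured in this assay. It departs from compound 2 in one place: chloro in place of hydrogen on an aromatic carbon. Put simply, this is chloro in place of hydrogen on an aromatic carbon. Among the measured compounds shown here, no measured pair yet shows what a single change of this kind does to the half-life, so the data offer no size or direction for it. For the measured compounds named here, the only guide is the level shared by the two measured compounds, with compound 1 at 1.49 h and compound 2 at 1.54 h. No shift beyond the scatter is therefore expected in this assay, and the expected change is only a 1.0-fold lower number from compound 2 to compound 3 (0.01 log units; within the scatter). For compound 3 the estimated half-life is 1.5 h, with an expected range from 1 h to 2.2 h.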

Compound 3, half-life in the CCRF-CEM assay: 2.52 h
For compound 3 the middle estimate is 1.7-fold (0.23 log units) below the measured one; the whole stated range lies below it.
By their numbers in the CCRF-CEM assay, from the lowest: compounds 1, 2 and 3 (each within the scatter of the next).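

Among the compounds shown here, this is the first step that changes a single place, and it puts chloro in place of hydrogen on an aromatic carbon of the six-membered aromatic ring with 2 nitrogen: in the CCRF-CEM assay the change gives a 1.6-fold higher number from compound 2 to compound 3 (0.21 log units; within the scatter), so this pair cannot be ranked and the position accepts chloro with no readable shift in half-life in cells. In a physicochemical assay for metabolic stability, read by HPLC, in phosphate buffer, at pH 7.3 (a lower number here means that the compound disappears faster, a higher number that the compound lasts longer), the same change gives a 1.0-fold lower number from compound 2 to compound 3 (0.01 log units; within the scatter), with compound 2 at 68 h and compound 3 at 67 h, so the chloro group also brings no readable shift in buffer. No measurement shown here offers a reason for either result.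

Going by these compounds, these compounds cover only hydrogen and chloro at this position, so it remains open whether a larger or different group there, such as bromo, methoxy or an amine, would move the half-life beyond the scatter. The chloro change is also seen on just one pair, so whether it behaves the same way on the core of compound 1 remains an open question.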